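Methoxy to Hydroxy in a Small Antiproliferative Series

The source may report more compounds than this note shows. Statements on the series, on what has been measured and on what is new or still open speak of the compounds shown alone.

In a functional assay on SW480 cells (Homo sapiens) for antiproliferative activity, read by sulforhodamine B assay, with a stated time of 48 h (on this read-out higher numbers stand for weaker inhibition and lower numbers for stronger inhibition), compound 1 (`COc1ccc(/C=C/C(=O)c2ccccc2-c2cccc(F)c2)cc1`) gives 140 nM and compound 2 (`COc1ccc(/C=C/C(=O)c2ccccc2-c2cccc(F)c2)cc1OC`) gives 160 nM, so compound 2 stands level with compound 1 within the scatter. Compound 3 (`COc1ccc(/C=C/C(=O)c2ccccc2-c2cccc(F)c2)cc1O`) differs from compound 2 by hydrogen in place of methyl on an oxygen on an aromatic ring, or methoxy to hydroxy. For the measured compounds named here, the only measured step, a 1.1-fold higher number from compound 1 to compound 2 (0.06 log units; within the scatter), is a different change, methoxy in place of hydrogen on an aromatic carbon, so it bears only indirectly. No step beyond the scatter is therefore expected in this assay. The estimated step is a 1.1-fold lower number from compound 2 to compound 3 (0.03 log units; within the scatter). Compound 3 is expected at 150 nM, with an estimated range of 60 nM to 350 nM.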

Compound 3, half-maximal inhibitory concentration: 10 nM
Compound 3: the middle estimate sits 15-fold (1.18 log units) above what was measured; the measured number lies below the stated range.
By their numbers in this assay, from the lowest: compound 3; then compounds 1 and 2 (each within the scatter of the next).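

In this assay this place, which took methoxy with no step beyond the scatter, proves sensitive to hydroxy: hydrogen in place of methyl on the oxygen gives a 16-fold lower number from compound 2 to compound 3 (1.20 log units; beyond the scatter) and hydroxy in place of hydrogen on the aromatic carbon gives a 14-fold lower number from compound 1 to compound 3 (1.15 log units; beyond the scatter) as well. Both steps end at compound 3, so in these compounds the large change appears only with hydroxy, and not with methoxy or hydrogen. Nothing available explains this difference.

As far as these compounds go, whether an amine at this place, or an ethoxy group on the same oxygen, would hold the lower number remains open.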